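The compounds below may be only part of what the source reports. "The series", "measured", "known", "first", "only" and "open" are said of these compounds alone.

Of the compounds shown here, three have been tested in a functional assay on the whole organism for antagonist activity, with Mus musculus as the target (a lower number here means that less compound is needed, a higher number that more compound is needed for the effect), and none of them yields a number. Compound 1 (`CC(=O)N(C)CC#CCN1CCCC1`) gives > 10 mg/kg, a limit of the assay. Compound 2 (`COC(=O)N(C)CC#CCN1CCCC1`) gives > 10 mg/kg, also a limit. Compound 3 (`COC(=O)N(C)CC#CCn1ccnc1`) gives > 100 mg/kg, again a limit. Compound 2 therefore stands at the limit of > 10 mg/kg in this assay, at which 2 of the 3 values shown sit.

Compound 4 (`COC(=O)N(C)C(C)C#CCN1CCCC1`) carries a single change from compound 2: methyl in place of hydrogen on a saturated chain carbon bound to an amide-type nitrogen and a triple-bonded carbon.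

The measured steps offer little guidance. Among the measured compounds shown here, the first is a step that the two limits leave unreadable from compound 1 to compound 2. The second is a step that the two limits leave unreadable from compound 2 to compound 3. Neither has a readable size, and neither places a methyl on this carbon, so no firm size or direction carries over to this assay. The estimated change is a step that the limit leaves unreadable from compound 2 to compound 4, and this expectation is a loose one. Compound 4 is expected at 20 mg/kg, with an estimated range from 5 mg/kg to 80 mg/kg.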

Compound 4, dose for half-maximal effect: > 100 mg/kg
Compound 4 ended at the assay's limit (the forecaster's own chance of this, stated with the estimate: 60%); middle value at least 5.0-fold (0.69 log units) from the limit.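

In this assay, compound 2 and compound 4 both end at limits and give no numbers, so the step between them cannot be read. The compounds shown leave open how large the effect of methyl in place of hydrogen on this carbon is, and in which direction it runs.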